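Compound 3 to compound 4: allyl replaced by acetyl

The compounds below may be only part of what the source reports. "The series", "measured", "known", "first", "only" and "open" are said of these compounds alone.

Values in a functional assay on NCI-H1581 cells (Homo sapiens) for antiproliferative activity, read by CCK-8 assay, with a stated time of 72 h; a lower number here means a stronger inhibitor, a higher number a weaker inhibitor:
- compound 1 `COc1cc(OC)c(Cl)c(-c2ccc3c(NC(=O)c4ccc(C5CCN(C)CC5)cc4)n[nH]c3n2)c1Cl`: 8.2 nM
- compound 2 `COc1cc(OC)c(Cl)c(-c2ccc3c(NC(=O)c4ccc(N5CCCN(C)CC5)cc4)n[nH]c3n2)c1Cl`: 1.3 nM
- compound 3 `C=CCN1CCN(c2ccc(C(=O)Nc3n[nH]c4nc(-c5c(Cl)c(OC)cc(OC)c5Cl)ccc34)cc2)CC1`: 3.3 nM

In this assay compound 3 at 3.3 nM stands second highest of the three values, between the other two compounds. Compound 4 `COc1cc(OC)c(Cl)c(-c2ccc3c(NC(=O)c4ccc(N5CCN(C(C)=O)CC5)cc4)n[nH]c3n2)c1Cl` carries acetyl in place of allyl on an amine nitrogen in a ring. Within the data shown here, no measured step makes this exchange on an intact ring. The nearest evidence comes from swapping the whole group on the aromatic carbon: a 2.5-fold lower number from compound 1 to compound 3 (0.40 log units; beyond the scatter), a 2.5-fold higher number from compound 2 to compound 3 (0.40 log units; beyond the scatter) and a 6.3-fold lower number from compound 1 to compound 2 (0.80 log units; beyond the scatter). All three steps are modest, so a step of similar modest size is expected for a smaller edit at the far end of that group. The data do not fix its direction, and a higher number is judged the likelier outcome, with a wide margin on either side. The estimated step is a 2.1-fold higher number from compound 3 to compound 4 (0.33 log units; beyond the scatter). In this assay the expected value for compound 4 is 7 nM, with an estimated range of 2 nM to 25 nM.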

Compound 4, half-maximal inhibitory concentration: 43.3 nM
Beside the measured number, compound 4's estimate is 6.2-fold (0.79 log units) below it, outside the stated range (above it).
By their numbers in this assay, from the lowest: compound 2; then compound 3; then compound 1; then compound 4.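

On the amine nitrogen of the six-membered ring, acetyl in place of allyl gives a 13-fold higher number from compound 3 to compound 4 (1.12 log units; beyond the scatter) in this assay, so a swap between two groups of equal heavy-atom count can produce a large step here, whereas the steps among compound 1, compound 2 and compound 3 were all modest. The whole-group swaps to 4-acetylpiperazin-1-yl run the same way, with a 33-fold higher number from compound 2 to compound 4 (1.52 log units; beyond the scatter) and a 5.3-fold higher number from compound 1 to compound 4 (0.72 log units; beyond the scatter), which leaves compound 4 the weakest of the four in this assay. Nothing measured here accounts for this loss.

Still open, as far as these compounds go, is whether the loss goes with acetyl alone: a methanesulfonyl, a cyclopropanecarbonyl or a plain ethyl group on the same ring nitrogen would bear on that. Also open, from the compounds shown here alone, is whether acetyl in place of methyl in the 4-methyl-1,4-diazepan-1-yl group of compound 2 would give a step of similar size.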